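Adding a chloro group to a thiazole-linked antiproliferative series

The source may report more compounds than this note shows. Statements on the series, on what has been measured and on what is new or still open speak of the compounds shown alone.

Three measured compounds share a thiazole part joined through a carbonyl and a sulfur link to a second heteroaromatic ring. Compound 1 `Cc1nc(-c2ccc(Cl)cc2)sc1C(=O)CSc1nc(-c2cccc(Cl)c2)c(C#N)c(=O)[nH]1` and compound 3 `Cc1nc(-c2ccccc2)sc1C(=O)CSc1nc(-c2cccc(Cl)c2)c(C#N)c(=O)[nH]1` carry the same second ring, while compound 2 `Cc1nc(-c2ccccc2)sc1C(=O)CSc1nc(N)c(C#N)c(-c2ccc(Cl)cc2)n1` carries a different one; the difference between the two cores is not broken down here. In a functional assay on U-87MG ATCC cells for antiproliferative activity against U-87 MG (Homo sapiens), read by MTT assay, with a stated time of 48 h, tested at 5 uM (a lower number here means a stronger effect, a higher number a weaker effect of the compound at the concentration tested), compound 1 gives 80.2% and compound 3 gives 86.9%. Their single difference, (chloro in place of hydrogen on an aromatic carbon), brought a number 6.7 percentage points lower from compound 3 to compound 1 (within the scatter). Compound 2 gives 62.9% in this assay, the strongest effect of the three, separated from both others by more than the usual scatter.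

Compound 4 `Cc1nc(-c2ccc(Cl)cc2)sc1C(=O)CSc1nc(N)c(C#N)c(-c2ccc(Cl)cc2)n1` is not yet measured. It differs from compound 2 by chloro in place of hydrogen on an aromatic carbon, the same change that turns compound 3 into compound 1. Resting on that earlier step, the change from compound 2 to compound 4 is expected to give a number 4.9 percentage points lower from compound 2 to compound 4 (within the scatter), beside a number 6.7 percentage points lower from compound 3 to compound 1 (within the scatter). Compound 4 is therefore estimated at 58% in this assay, with a likely range from 45% to 72%.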

Compound 4, a percentage reported as activity, at one concentration (the size of the read-out at that concentration, not a potency): 46.1%
For compound 4 the middle estimate is 11.9 percentage points above the measured one, and the stated range covers the measured number.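

On the core of compound 2, the change from phenyl to 4-chlorophenyl brought a number 16.8 percentage points lower from compound 2 to compound 4 (beyond the scatter) in this assay, a stronger effect at the concentration tested. The same change on the two cores gave steps that cannot be told apart, so the data fit a single shared effect of similar size, though they do not prove one: the same change on two cores in this assay, a number 6.7 percentage points lower (within the scatter) from compound 3 to compound 1 and a number 16.8 percentage points lower (beyond the scatter) from compound 2 to compound 4, 10.1 percentage points apart, within the scatter of two such steps. This does not show that the change lowers the number on every core. For the compounds shown here, only the step on the core of compound 2 lies beyond the usual scatter, and two cores are too few to fix the size of the step.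

The compounds shown leave open whether a fluoro, methyl or methoxy group in place of the chloro, still para to a large group, would act as the chloro does. They also leave open what an amine or a carboxylic acid would do at that carbon.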